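This account rests on a few compounds, and the source may have more. Where it says the series, first, only, none or still open, it means among the compounds named here.

Measured to date in a functional assay on MKN-45 cells (Homo sapiens) for cytotoxicity, read by MTT assay, with a stated time of 72 h; on this read-out higher numbers stand for weaker inhibition and lower numbers for stronger inhibition:

compound 1 `CN(C)CCNc1nc(-c2ccc(NC(=O)Nc3ccc(Cl)cc3)cc2)nc2ccsc12` – 250 nM
compound 2 `CN(C)CCNc1nc(-c2ccc(NC(=O)Nc3ccc(Cl)cc3Cl)cc2)nc2ccsc12` – 2360 nM
compound 3 `CCN(CC)CCNc1nc(-c2ccc(NC(=O)Nc3ccc(Cl)cc3)cc2)nc2ccsc12` – 370 nM

Compound 3 stands second highest of the three numbers in this assay. Its nearest neighbour is compound 1; the step of a 1.5-fold higher number from compound 1 to compound 3 (0.17 log units; within the scatter) is within the scatter, so the two are not separated. Compound 2 stands furthest from compound 3, beyond the scatter.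

Compound 4 `CCN(CC)CCNc1nc(-c2ccc(NC(=O)Nc3ccc(Cl)cc3Cl)cc2)nc2ccsc12` differs from compound 3 in one place: chloro in place of hydrogen on an aromatic carbon. The same change has been measured once, between compound 1 and compound 2, where it gave a 9.4-fold higher number from compound 1 to compound 2 (0.97 log units; beyond the scatter), clearly beyond the scatter. Among the measured compounds shown here, that is the only step that bears on the pair. The other measured step, a 1.5-fold higher number from compound 1 to compound 3 (0.17 log units; within the scatter), shows that swapping the amine substituent leaves the number essentially unchanged, so there is no sign that the diethylamino series should respond differently to the added chloro group than the dimethylamino series did.

The step from compound 3 to compound 4 is therefore expected to be upward, towards weaker inhibition, of about the size seen before: a 9.5-fold higher number from compound 3 to compound 4 (0.98 log units; beyond the scatter). For compound 4 the expected value is 3500 nM, with a range of 1500 nM to 8000 nM. For the measured compounds named here, only one prior example supports this, so the range is kept wide.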

Compound 4, half-maximal inhibitory concentration: 1520 nM
The estimate for compound 4 lay 2.3-fold (0.36 log units) above the measured number; the measured number falls inside the stated range.
By their numbers in this assay, from the lowest: compounds 1 and 3 (each within the scatter of the next); then compounds 4 and 2 (each within the scatter of the next).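

In this assay the move from 4-chlorophenyl to 2,4-dichlorophenyl now has a second reading, a 4.1-fold higher number from compound 3 to compound 4 (0.61 log units; beyond the scatter) and so the upward step beyond the scatter holds with both amine groups, while its size does not separate the two cores: the same change on two cores in this assay, a 9.4-fold higher number (0.97 log units; beyond the scatter) from compound 1 to compound 2 and a 4.1-fold higher number (0.61 log units; beyond the scatter) from compound 3 to compound 4, 2.3-fold (0.36 log units) apart, within the scatter of two such steps.

With 2,4-dichlorophenyl in place, diethylamino for dimethylamino gives a 1.6-fold lower number from compound 2 to compound 4 (0.19 log units; within the scatter) and so leaves the number as unseparated as it did with 4-chlorophenyl: the same change on two cores in this assay, a 1.5-fold higher number (0.17 log units; within the scatter) from compound 1 to compound 3 and a 1.6-fold lower number (0.19 log units; within the scatter) from compound 2 to compound 4, 2.3-fold (0.36 log units) apart, within the scatter of two such steps.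

Across these four compounds the two changes therefore read as independent, with the added chloro moving the number and the amine swap not.

Open, on these data alone, is whether a fluoro or methoxy group at this place, ortho to a large group, would give the same upward step as chloro. Also open, as far as these compounds go, is whether a primary amine or a longer chain at the amine end would stay as unseparated as diethylamino.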